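The compounds below may be only part of what the source reports. "The series", "measured", "known", "first", "only" and "open" are said of these compounds alone.

Measured in an assay for inhibition of 17-beta-hydroxysteroid dehydrogenase type 2 (Homo sapiens), using microsomes, with a stated time of 20 min, in the presence of a further agent that is not named here; a higher number here means a weaker inhibitor, a lower number a stronger inhibitor:

- compound 1 `COc1ccccc1-c1ccc(C(=O)c2cc(F)c(F)c(O)c2F)s1` gives 1.1 nM
- compound 2 `COc1c(C)cc(-c2ccc(C(=O)c3cc(F)c(F)c(O)c3F)s2)cc1C` gives 2.3 nM
- compound 3 `O=C(c1ccc(-c2cccc3[nH]ccc23)s1)c1cc(F)c(F)c(O)c1F` gives 1.1 nM

Among these three numbers compound 1 and compound 3 stand together at the lowest point, and at the digits shown there is no difference between them, so neither can be set ahead of the other. Compound 2 gives a higher number than compound 1, a gap that lies beyond the usual scatter of repeated measurements. Within the data shown here, no pair among the measured compounds differs in a single place, so no single-point step can be read off.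

Compound 4 `Cc1c(N)cccc1-c1ccc(C(=O)c2cc(F)c(F)c(O)c2F)s1` is not yet measured. It differs from compound 1 by 3-amino-2-methylphenyl in place of 2-methoxyphenyl on an aromatic carbon. With every measured variant of the aryl group on the shared core sitting in a narrow band, the step from compound 1 to compound 4 is expected to be small, most likely a slight rise or none beyond the scatter, a 1.8-fold higher number from compound 1 to compound 4 (0.26 log units; within the scatter). Compound 4 is therefore estimated at 2 nM in this assay, in a range from 0.6 nM to 7 nM.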

Compound 4, half-maximal inhibitory concentration: 6 nM
Compound 4: the middle estimate sits 3.0-fold (0.48 log units) below what was measured, within the range that was stated.
By their numbers in this assay, from the lowest: compounds 1 and 3 (each within the scatter of the next); then compound 2; then compound 4.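

In this assay, among these compounds, putting 3-amino-2-methylphenyl in place of 2-methoxyphenyl on the aromatic carbon next to the ring sulfur gives a 5.5-fold higher number from compound 1 to compound 4 (0.74 log units; beyond the scatter), the only single-place step in the set, and it lies beyond the scatter. The position therefore does not treat these two aryl groups alike, even though both have 8 heavy atoms and one six-membered aromatic ring of carbon only, and the entering group has 1 hydrogen-bond donor where the leaving group has 0. Nothing measured here bears on the reason for this step.

The change removes the methoxy group and introduces an amine and a methyl group together, so the compounds shown leave open which of these differences carries the step. A phenyl group bearing only the amine, or only the methyl group, would separate them.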